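Triazole Ring in Place of the Chain Hydroxyl

This account rests on a few compounds, and the source may have more. Where it says the series, first, only, none or still open, it means among the compounds named here.

Compound 1, `CCCCNc1nc(N)nc(C)c1CCCCO`, gives 1310 nM in an assay on HEK293 cells for agonist activity at Toll-like receptor 8 (Homo sapiens), read by spectrophotometry; a higher number here means that more compound is needed for the effect, a lower number that less compound is needed.
Compound 2, `CCCCNc1nc(N)nc(C)c1CC`, gives 1660 nM in this assay.

Compound 1 has the lower of the two numbers in this assay, but its gap to compound 2, a 1.3-fold higher number from compound 1 to compound 2 (0.10 log units; within the scatter), lies within the scatter, so the two cannot be ordered. Compound 3, `CCCCNc1nc(N)nc(C)c1CCCn1cncn1`, differs from compound 1 by 1H-1,2,4-triazol-1-yl in place of hydroxymethyl on a saturated chain carbon, three bonds along the chain from an aromatic carbon. Among the compounds with values here, only one measured step bears on this change: a 1.3-fold higher number from compound 1 to compound 2 (0.10 log units; within the scatter), which removed the 2-hydroxyethyl and left the number within the scatter. Within the data shown here, that step suggests alteration at the outer end of this chain has so far moved the number little, though no compound carrying a ring at this place has been measured. Compound 3 is therefore expected to stay close to compound 1, with a 1.1-fold lower number from compound 1 to compound 3 (0.04 log units; within the scatter) as the expected step. The estimated value for compound 3 is 1200 nM, within a range from 400 nM to 3600 nM.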

Compound 3, half-maximal effective concentration: 1050 nM
Compound 3: middle estimate off by 1.1-fold (0.06 log units), on the high side; measured number inside the range.
By their numbers in this assay, from the lowest: compounds 3, 1 and 2 (each within the scatter of the next).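

In this assay, the exchange of hydroxymethyl for 1H-1,2,4-triazol-1-yl gives a 1.2-fold lower number from compound 1 to compound 3 (0.10 log units; within the scatter) and so stays within the scatter, even though a five-membered aromatic ring with 3 hetero atoms enters and the hydrogen-bond donor of the leaving group is gone. Set against compound 2, (1H-1,2,4-triazol-1-yl)methyl in place of hydrogen gives a 1.6-fold lower number from compound 2 to compound 3 (0.20 log units; within the scatter) and likewise cannot be told from no change, so this position has now taken a ring as well as a hydroxyl-ended chain without a step beyond the scatter. Nothing measured on these compounds speaks to the reason for this.

Going by these compounds, whether any group at this place can move the number beyond the scatter stays open. An amine or a carboxylic acid at the chain end, or a longer chain carrying the triazole, could still answer that.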